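This account rests on a few compounds, and the source may have more. Where it says the series, first, only, none or still open, it means among the compounds named here.

Of the compounds shown here, three built on a shared core have been tested so far in a functional assay on MCF7 cells (Homo sapiens) for inhibition, read by MTT assay, with a stated time of 48 h; a higher number here means a weaker inhibitor, a lower number a stronger inhibitor. Compound 1 (`O=C(CC(c1ccc(Cl)cc1)C(C(=O)Nc1ccccn1)C(=O)Nc1ccccn1)c1ccccc1`) gives 19100 nM. Compound 2 (`O=C(CC(c1ccccc1)C(C(=O)Nc1ccccn1)C(=O)Nc1ccccn1)c1ccc(F)cc1`) is reported as "not active" (no number reported), with no number attached. Going by the values given here, compound 3 (`O=C(CC(c1ccc(F)cc1)C(C(=O)Nc1ccccn1)C(=O)Nc1ccccn1)c1ccc(F)cc1`) gives 23300 nM, a value within the usual scatter of the one for compound 1, so these two cannot be told apart in this assay.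

Compound 4 (`O=C(CC(c1ccc(Cl)cc1)C(C(=O)Nc1ccccn1)C(=O)Nc1ccccn1)c1ccc(F)cc1`) departs from compound 3 by a single change: chloro in place of fluoro on an aromatic carbon. Put simply, this is chloro in place of fluoro on an aromatic carbon, turning a 4-fluorophenyl into a 4-chlorophenyl. Among the compounds with values here, no two measured compounds differ in only one place, so the effect of this swap has not been measured directly. The nearest guide is compound 1, which also carries a 4-chlorophenyl and gives 19100 nM. The expected change is small, with an estimated 1.1-fold lower number from compound 3 to compound 4 (0.05 log units; within the scatter), which would stay within the scatter. For compound 4 the estimated value is 21000 nM, with an expected range from 11000 nM to 40000 nM.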

Compound 4, half-maximal inhibitory concentration: 21200 nM
Compound 4: middle estimate off by 1.0-fold (0.00 log units), on the low side; the range from low to high includes it.
By their numbers in this assay, from the lowest: compounds 1, 4 and 3 (each within the scatter of the next).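

In this assay, going by these compounds alone, replacing the 4-fluorophenyl with a 4-chlorophenyl gives a 1.1-fold lower number from compound 3 to compound 4 (0.04 log units; within the scatter) and so provides the first direct reading of this change, which leaves the two compounds indistinguishable. On the other aromatic ring, fluoro in place of hydrogen gives a 1.1-fold higher number from compound 1 to compound 4 (0.05 log units; within the scatter) and likewise leaves the two compounds indistinguishable. No measurement at hand offers an explanation for either result.

From the compounds shown here alone, both changes stay among hydrogen, fluoro and chloro, so it remains open whether a methoxy group, an amine or a carboxylic acid in the same place would shift the number beyond the scatter. Within the data shown here, also open is how the rest of the shared core contributes, and compound 2, reported as "not active" with no number, gives no size for the step from compound 2 to compound 3.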